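The source may hold more compounds than are shown below. What is called first, only, known or untested is meant among the compounds shown, and "the series" means these compounds.

Working notes on the diacylhydrazine series in an assay on cells for agonist activity at ecdysone receptor (Bombyx mori), read by a luciferase reporter, with a stated time of 24 h; on this read-out lower numbers stand for an effect already at smaller amounts and higher numbers for an effect only at larger amounts of compound.

Of the compounds shown here, three have been measured. Compound 1 `CC(C)(C)N(NC(=O)c1ccccc1)C(=O)c1ccccc1Br` gives 170 nM. Within the data shown here, compound 2 `CC(C)(C)N(NC(=O)c1ccccc1)C(=O)c1ccccc1C(F)(F)F` gives 631 nM; the only single-point step in the set, a 3.7-fold higher number from compound 1 to compound 2 (0.57 log units; beyond the scatter), lies on the benzoyl attached directly to the substituted nitrogen. Compound 3 `Cc1ccccc1C(=O)NN(C(=O)c1ccccc1Cl)C(C)(C)C` gives 72.4 nM and stands lowest of the three numbers, with compound 1 the nearest and compound 2 the furthest.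

Compound 4 `Cc1ccc(C(=O)NN(C(=O)c2ccccc2Cl)C(C)(C)C)cc1` has not been measured. It differs from compound 3 in one place: 4-methylphenyl in place of 2-methylphenyl on a carbonyl carbon. Among the measured compounds shown here, the change sits on the benzoyl carried by the amide-type nitrogen, not on the ring that was varied between compound 1 and compound 2, so no measured step bears directly on it; the step from compound 1 to compound 2 concerns a different ring and a different kind of substituent. Nothing in the set tells how moving the methyl around this ring shifts the read-out.

Taking this as an untested change, the expectation is no step beyond the scatter, so a 1.2-fold lower number from compound 3 to compound 4 (0.08 log units; within the scatter) is expected to be small. For compound 4 the estimate is 60 nM, with a range from 15 nM to 250 nM.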

Compound 4, half-maximal effective concentration: 18.6 nM
The estimate for compound 4 lay 3.2-fold (0.51 log units) above the measured number; measured number inside the range.
By their numbers in this assay, from the lowest: compound 4; then compound 3; then compound 1; then compound 2.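

With the same atoms joined differently, 4-methylphenyl in place of 2-methylphenyl on a carbonyl carbon gives, in this assay, a 3.9-fold lower number from compound 3 to compound 4 (0.59 log units; beyond the scatter), so the read-out depends on where the methyl sits on this ring. The earlier single-place step, a 3.7-fold higher number from compound 1 to compound 2 (0.57 log units; beyond the scatter), concerned a different ring and a change of substituent, and so gave no view of this position or of a shift in substituent placement. Nothing available accounts for the lower number seen with 4-methylphenyl.

Still open, going by these compounds, is how an ethyl chain, a methoxy group or an amine would read in place of the methyl of 4-methylphenyl. Also open, on these data alone, is whether the same step would appear with bromo or trifluoromethyl in place of the chloro of compound 4.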